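The source may hold more compounds than are shown below. What is called first, only, known or untested is meant among the compounds shown, and "the series" means these compounds.

In a functional assay on THP-1 cells (Homo sapiens) for inhibition (on this read-out lower numbers stand for stronger inhibition of growth and higher numbers for weaker inhibition of growth), compound 1 `Cc1noc(C)c1-c1ccc2c(c1)c(Cc1ccccc1)cn2CCCCCCC(=O)NO` gives 15500 nM. Two close relatives stand level with it: compound 2 `Cc1noc(C)c1-c1ccc2c(c1)c(Cc1ccc(F)cc1)cn2CCCCCC(=O)NO` gives 15500 nM, and compound 3 `Cc1cccc(Cc2cn(CCCCCC(=O)NO)c3ccc(-c4c(C)noc4C)cc23)c1` gives 15500 nM. Compound 4 `Cc1ccc(Cc2cn(CCCCCCC(=O)NO)c3ccc(-c4c(C)noc4C)cc23)cc1` has yet to be measured in this assay. It differs from compound 1 in one place, with methyl in place of hydrogen on an aromatic carbon. Put another way, benzyl becomes 4-methylbenzyl.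

Within the data shown here, the only measured single-place step that bears on this is no change at the digits printed from compound 2 to compound 3 (within the scatter), in which 3-methylphenyl replaces 4-fluorophenyl in the same part of the molecule. Among the measured compounds shown here, this is thin support, since no measured pair shows this exact swap of hydrogen for methyl. Even so, that one step stayed within the scatter, so no change beyond the scatter is expected here, and no direction can be favoured. The expected step is no change at the digits printed from compound 1 to compound 4 (within the scatter). The estimate for compound 4 is 15500 nM, with an expected range of 8000 nM to 28000 nM.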

Compound 4, concentration for 50% growth inhibition: 15500 nM
For compound 4 middle estimate and measured number coincide at the digits printed; the measured number falls inside the stated range.
By their numbers in this assay, from the lowest: compounds 1, 2, 3 and 4 (each within the scatter of the next).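

In this assay, going from benzyl to 4-methylbenzyl gives no change at the digits printed from compound 1 to compound 4 (within the scatter), so this exact swap of hydrogen for methyl now has a direct measurement, where before only the swap of 4-fluorophenyl for 3-methylphenyl bore on this part of the molecule. On this ring, at the place para to a large group, the added methyl therefore leaves the growth read-out of compound 1 unmoved. No measurement at hand can explain this result.

An amine, a carboxylic acid or a longer chain at this same place could still give a different number, and the compounds shown do not speak to those groups. On these data alone, with all four compounds level, it also remains open which change on this ring, if any, would move the read-out beyond the scatter.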